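Compound 2 to compound 3: losing tert-butoxycarbonyl

The compounds below may be only part of what the source reports. "The series", "measured", "known", "first", "only" and "open" are said of these compounds alone.

Two members of the series have been read so far in a functional assay on HCT-116 cells (Homo sapiens) for cytotoxicity, read by MTT assay, with a stated time of 72 h; on this read-out lower numbers stand for stronger inhibition and higher numbers for weaker inhibition: compound 1 `O=C(NCc1ccc(F)cc1)c1nc(Br)c2cccnc2c1NCCCNc1c(C(=O)NCc2ccc(F)cc2)nc(Br)c2cccnc12` and compound 2 `CC(C)(C)OC(=O)N1CCN(c2c(C(=O)NCc3ccc(F)cc3)nc(Br)c3cccnc23)CC1`. Compound 1 gives > 20000 nM, which is a limit of the assay and not a number. Compound 2 gives > 10000 nM, which is also a limit and not a number. Within the data shown here, compound 2 therefore has no measured position, and no measured step is available for calibration.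

Compound 3 `O=C(NCc1ccc(F)cc1)c1nc(Br)c2cccnc2c1N1CCNCC1` carries hydrogen in place of tert-butoxycarbonyl on an amine nitrogen in a ring. Among the measured compounds shown here, no measured pair shows what this change does in this assay, so the expectation is a loose one. A moderate step towards stronger inhibition is expected, beyond the usual scatter if a number is obtained at all, although compound 3 may also end at a limit. The expected step is an at least 1.6-fold lower number from compound 2 to compound 3 (0.22 log units; that floor lies within the scatter). The estimated value for compound 3 is 6000 nM, with an expected range from 1200 nM to 25000 nM.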

Compound 3, half-maximal inhibitory concentration: > 10000 nM
Compound 3: only a limit was reported; the forecaster's own chance of this, stated with the estimate: 35%; middle value at least 1.6-fold (0.22 log units) from the limit.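

In this assay compound 2 gives > 10000 nM, a limit and not a number. Compound 3 gives > 10000 nM, also a limit. Among these compounds, no step between compound 2 and compound 3 can be read from these two limits. The compounds shown leave open whether hydrogen in place of tert-butoxycarbonyl on an amine nitrogen in a ring changes inhibition in this assay at all.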